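Acetylation of a hydroxy group in a styryl lactone series

The compounds below may be only part of what the source reports. "The series", "measured", "known", "first", "only" and "open" are said of these compounds alone.

Measured so far in a functional assay on RAW264.7 cells (Mus musculus) for inhibition, read by Griess assay, with a stated time of 18 h; a lower number here means a stronger inhibitor, a higher number a weaker inhibitor:
compound 1 `CC(=O)O[C@H](C[C@@H](O)C[C@H](O)/C=C/c1ccccc1)C[C@H]1CC=CC(=O)O1`: a limit, > 50000 nM
compound 2 `O=C(O)O[C@H](C[C@@H](O)C[C@H]1CC=CC(=O)O1)C[C@H](O)/C=C/c1ccccc1`: a limit, > 50000 nM

Compound 2 sits at the limit of this assay and gives no number. Compound 1 also sits at a limit, so the two values show no gap between them; the limit of > 50000 nM in this assay, at which 2 of the 2 values shown sit, marks where both stand. Compound 3 `CC(=O)O[C@H](C[C@H](C[C@H](O)/C=C/c1ccccc1)OC(=O)O)C[C@H]1CC=CC(=O)O1` differs from compound 2 by acetyl in place of hydrogen on an oxygen on a saturated carbon, hydroxy to acetoxy. With both measured compounds at a limit, the step that the limit leaves unreadable from compound 2 to compound 3 is expected to stay within the scatter. Compound 3 is expected to give 80000 nM, between 30000 nM and 250000 nM, most likely reported as a limit again.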

Compound 3, half-maximal inhibitory concentration: > 50000 nM
Compound 3 was reported as a limit (the forecaster's own chance of this, stated with the estimate: 85%); the middle value does not contradict the limit.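

No step can be read among compound 1, compound 2 and compound 3, as all three stand at a limit: the limit of > 50000 nM in this assay, at which 3 of the 3 values shown sit.

The compounds shown leave open how strongly any of them inhibits, and whether hydroxy to acetoxy alters that at all.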